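The compounds below may be only part of what the source reports. "The series", "measured", "known", "first", "only" and "open" are said of these compounds alone.

The measured compounds, each with its result in an assay (Equus caballus) for inhibition of Thromboxane-A synthase (Homo sapiens), using microsomes; a higher number here means a weaker inhibitor, a lower number a stronger inhibitor:
compound 1, `Cc1ccsc1/C(=C/CCCCC(=O)O)c1cccnc1`, gives 29 nM;
compound 2, `O=C(O)CCCC/C=C(\c1cccnc1)c1cccc(F)c1`, gives 55 nM;
compound 3, `O=C(O)CCCC/C=C(\c1cccnc1)c1cccs1`, gives 20 nM.

Among these three numbers compound 3 holds the smallest, though only one gap is meaningful: the step of a 1.5-fold lower number from compound 1 to compound 3 (0.16 log units; within the scatter), while the step of a 2.8-fold lower number from compound 2 to compound 3 (0.44 log units; beyond the scatter). Compound 4, `Cc1ccc(/C(=C/CCCCC(=O)O)c2cccnc2)cc1`, has not yet been measured. It differs from compound 3 in one place: 4-methylphenyl in place of thiophen-2-yl on a double-bonded chain carbon bound to an aromatic carbon and a double-bonded chain carbon. Among the compounds with values here, two measured steps bear on this swap of thiophen-2-yl for a carbon-only six-membered ring. The step of a 2.8-fold lower number from compound 2 to compound 3 (0.44 log units; beyond the scatter) shows the lower number on the side of thiophen-2-yl, and the step of a 1.9-fold higher number from compound 1 to compound 2 (0.28 log units; within the scatter) points the same way, though it stays within the scatter. Neither is large. Compound 4 is therefore expected to give a somewhat higher number than compound 3, a step of about a 2.3-fold higher number from compound 3 to compound 4 (0.35 log units; beyond the scatter) in this assay. Compound 4 is estimated at 45 nM, with a likely range from 20 nM to 110 nM.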

Compound 4, half-maximal inhibitory concentration: 85 nM
For compound 4 the middle estimate is 1.9-fold (0.28 log units) below the measured one; low and high end bracket the measured number.
By their numbers in this assay, from the lowest: compounds 3, 1, 2 and 4 (each within the scatter of the next, the first and the last beyond it).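

On the double-bonded chain carbon, the carbon-only ring now stands apart from both sulfur-containing five-membered rings, with a 4.3-fold higher number from compound 3 to compound 4 (0.63 log units; beyond the scatter) and a 2.9-fold higher number from compound 1 to compound 4 (0.47 log units; beyond the scatter). The two carbon-only rings, however, cannot be told apart in this assay, with a 1.5-fold higher number from compound 2 to compound 4 (0.19 log units; within the scatter), and the pair of compound 1 and compound 2 goes against a clean split by ring type, since a 1.9-fold higher number from compound 1 to compound 2 (0.28 log units; within the scatter). Nothing measured here accounts for these differences.

The compounds shown leave open whether the gap follows the ring itself or the substituent it carries, as 4-methylphenyl differs from thiophen-2-yl in both. A plain phenyl ring would separate those two changes, and a furan-2-yl ring, with oxygen in place of sulfur, would test whether sulfur matters.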